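Adding an Amino Group to Compound 1

The compounds below may be only part of what the source reports. "The series", "measured", "known", "first", "only" and "open" are said of these compounds alone.

Measured so far:
compound 1 `c1ccc(COc2cc3n(n2)CCCC3)nc1`: 2500 nM
compound 2 `Clc1ccnc(COc2cc3n(n2)CCCC3)c1`: > 10000 nM, a limit

Among the compounds with values here, in a functional assay on HEK293 cells for negative allosteric modulation of metabotropic glutamate receptor 5 (Rattus norvegicus), read by FLIPR and calcium flux, with a stated time of 170 s (on this read-out lower numbers stand for stronger inhibition and higher numbers for weaker inhibition), compound 1 gives 2500 nM, the only plain number among the two values shown. Compound 2 reaches only a limit of > 10000 nM in this assay, which is the limit of > 10000 nM in this assay, at which 1 of the 2 values shown sits. Within the data shown here, the one measured step is an at least 4.0-fold higher number from compound 1 to compound 2 (0.60 log units; beyond the scatter), brought about by chloro in place of hydrogen on an aromatic carbon.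

Compound 3 `Nc1cccc(COc2cc3n(n2)CCCC3)n1` differs from compound 1 as follows: amino in place of hydrogen on an aromatic carbon. Among the measured compounds shown here, the only measured step also adds a group on an aromatic carbon of the same ring, but the entering group there is chloro, not amino, so it bears on the new step only loosely. For the measured compounds named here, still, that step is the sole guide, and a weakening is expected, of about a 2.4-fold higher number from compound 1 to compound 3 (0.38 log units; beyond the scatter). Compound 3 is therefore estimated at 6000 nM, with a range from 1500 nM to 25000 nM.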

Compound 3, half-maximal inhibitory concentration: "not active" (no number reported)
Compound 3 has no reported number here; the estimate stays without a comparison.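

Within the data shown here, compound 3 is reported only as "not active", with no number, so no step from compound 1 to compound 3 can be read. The compounds shown leave open how far amino in place of hydrogen changes inhibition, and plain numbers are scarce here: the limit of > 10000 nM in this assay, at which 1 of the 3 values shown sits.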